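Aryl amide variation on a shared core, three points

The source may hold more compounds than are shown below. What is called first, only, known or untested is meant among the compounds shown, and "the series" means these compounds.

Measured so far in a functional assay on A549 cells (Homo sapiens) for antiproliferative activity, read by CCK-8 assay, with a stated time of 72 h; a lower number here means a stronger inhibitor, a higher number a weaker inhibitor:
compound 1 `COc1ccccc1C(=O)Nc1cccc(-c2oc3cc(-c4ccc(F)cc4)ccc3c(=O)c2O)c1` gives 11700 nM
compound 2 `O=C(Nc1cccc(-c2oc3cc(-c4ccc(F)cc4)ccc3c(=O)c2O)c1)c1ccc(C(F)(F)F)cc1` gives 19400 nM
compound 3 `Cc1cccc(C(=O)Nc2cccc(-c3oc4cc(-c5ccc(F)cc5)ccc4c(=O)c3O)c2)c1` gives 16500 nM

Compound 3 stands second highest of the three numbers, with both neighbours within the scatter: a 1.2-fold lower number from compound 2 to compound 3 (0.07 log units; within the scatter) and a 1.4-fold higher number from compound 1 to compound 3 (0.15 log units; within the scatter). All three compounds share the same core and differ only in the aryl group on the amide carbonyl carbon.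

Compound 4 `COc1ccc(C(=O)Nc2cccc(-c3oc4cc(-c5ccc(F)cc5)ccc4c(=O)c3O)c2)c(F)c1` continues that series: 2-fluoro-4-methoxyphenyl in place of 3-methylphenyl on a carbonyl carbon. Every measured step bears on it, since each is likewise an aryl swap at that carbonyl carbon: a 1.7-fold higher number from compound 1 to compound 2 (0.22 log units; within the scatter), a 1.4-fold higher number from compound 1 to compound 3 (0.15 log units; within the scatter), a 1.2-fold lower number from compound 2 to compound 3 (0.07 log units; within the scatter). None of them leaves the scatter, so three quite different aryl groups give indistinguishable numbers. The entering group carries a methoxy, as does compound 1, which gives 11700 nM, again within the scatter of the others.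

No step beyond the scatter is therefore expected in this assay; the estimated step is a 1.2-fold lower number from compound 3 to compound 4 (0.07 log units; within the scatter). Compound 4 is estimated at 14000 nM, expected between 6000 nM and 35000 nM.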

Compound 4, half-maximal inhibitory concentration: 40000 nM
For compound 4 the middle estimate is 2.9-fold (0.46 log units) below the measured one; the measured number lies above the stated range.
By their numbers in this assay, from the lowest: compounds 1, 3 and 2 (each within the scatter of the next); then compound 4.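

In this assay the aryl group on the carbonyl carbon now makes a measurable difference: 2-fluoro-4-methoxyphenyl brings a 2.4-fold higher number from compound 3 to compound 4 (0.38 log units; beyond the scatter) and a 2.1-fold higher number from compound 2 to compound 4 (0.31 log units; beyond the scatter) and a 3.4-fold higher number from compound 1 to compound 4 (0.53 log units; beyond the scatter), whereas the three earlier aryl groups stayed within the scatter of one another. A methoxy in the aryl group does not alone decide the outcome, as 2-methoxyphenyl in compound 1 stays with compounds 2 and 3 while 2-fluoro-4-methoxyphenyl in compound 4 does not. No measured evidence accounts for this separation.

Going by these compounds, whether the step follows the fluorine, the methoxy or the two together remains open, and 2-fluorophenyl and 4-methoxyphenyl amides would separate them. Also open, on these data alone, is the response to a different kind of substituent on the aryl ring, such as a carboxylic acid or an amine.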